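Swapping One Thiazole Ring for Another in a Bioavailability Series

A few compounds are considered here, and "the series" means these few. Any claim that something is new, unique, unknown or untested is made for them only; others in the source may bear on it.

Compound 1 `C[C@@H](Cn1c(=O)[nH]/c(=N\c2ccc(Oc3nccs3)cc2)n(Cc2ccc(Cl)cc2)c1=O)C(=O)O`: 41.4%
Compound 2 `CC(C)Oc1ccc(/N=c2\[nH]c(=O)n(C[C@@H](O)CO)c(=O)n2Cc2ccc(Cl)cc2)cc1Cl`: 63%
Compound 3 `Cc1ccc(Cn2c(=O)n(CC(C)(C)C(=O)O)c(=O)[nH]/c2=N\c2ccc(OC(C)C)c(Cl)c2)cc1`: 30.7%

Of the compounds shown here, three sharing one core have so far been tested in an ADME assay on the whole organism (Rattus norvegicus) for pharmacokinetics, using cassette dosing, at a dose of 1 mg/kg by the oral route; on this read-out lower numbers stand for lower oral bioavailability and higher numbers for higher oral bioavailability. Compound 1 gives 41.4%, which places it second highest of the three numbers. Its nearest neighbour is compound 3, whose 30.7% lies below it by a gap beyond the usual scatter of this assay. The furthest is compound 2, whose 63% lies above compound 1, again by a gap beyond the scatter.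

The next compound, compound 4 `C[C@@H](Cn1c(=O)[nH]/c(=N\c2ccc(Oc3ccsn3)cc2)n(Cc2ccc(Cl)cc2)c1=O)C(=O)O`, keeps every atom of compound 1 and rearranges only one small ring:

1,2-thiazol-3-yl in place of 1,3-thiazol-2-yl on an oxygen on an aromatic ring

Going by the values given here, no two of the measured compounds differ in a single place, so there is no measured step of this kind to lean on. The change is a rearrangement of the same atoms within one five-membered aromatic ring, with the same count of hydrogen-bond donors and acceptors, and I expect it to move the oral bioavailability little, if at all, with no direction beyond the scatter.

For compound 4 my estimate in this assay is 40%, within 25% to 56%. Relative to its parent, I expect a step of a number 1.4 percentage points lower from compound 1 to compound 4 (within the scatter).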

Compound 4, oral bioavailability: 87.6%
For compound 4 the middle estimate is 47.6 percentage points below the measured one; the whole stated range lies below it.
By their numbers in this assay, from the lowest: compound 3; then compound 1; then compound 2; then compound 4.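

In this assay, placing 1,2-thiazol-3-yl in place of 1,3-thiazol-2-yl on an oxygen on an aromatic ring gives a number 46.2 percentage points higher from compound 1 to compound 4 (beyond the scatter). This position is therefore sensitive to the arrangement of atoms within the ring, even though the two groups match in heavy atoms, hydrogen-bond donors, hydrogen-bond acceptors and net charge, so these counts alone do not tell the two groups apart in this read-out. No measurement shown here accounts for the size of this step.

From the compounds shown here alone, this is a single pair, so it remains open whether the same ring swap would give a similar step on a compound with a different acid or alcohol chain on the shared core. Going by these compounds, it also remains open how other rings on this oxygen would compare with the two thiazoles, such as 1,2-oxazol-3-yl, 1,3-oxazol-2-yl or pyridin-2-yl, and those would show whether the 1,2-thiazol-3-yl arrangement itself is special.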